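Diethylcarbamoyl in place of dimethylcarbamoyl on the nitrogen

This account rests on a few compounds, and the source may have more. Where it says the series, first, only, none or still open, it means among the compounds named here.

Measured compounds in an assay on isolated protein for binding affinity to cysteinyl leukotriene receptor 1 (Cavia porcellus); on this read-out lower numbers stand for stronger inhibition and higher numbers for weaker inhibition:
compound 1, `COc1cc(C(=O)NS(=O)(=O)c2ccccc2C)ccc1Cc1cn(C=O)c2ccc(NC(=O)OC3CCCC3)cc12`: 1 nM
compound 2, `COc1cc(C(=O)NS(=O)(=O)c2ccccc2C)ccc1Cc1c[nH]c2ccc(NC(=O)OC3CCCC3)cc12`: 1 nM
compound 3, `COc1cc(C(=O)NS(=O)(=O)c2ccccc2C)ccc1Cc1cn(C(=O)N(C)C)c2ccc(NC(=O)OC3CCCC3)cc12`: 0.4 nM

Compound 3 gives the lowest of the three numbers in this assay. Both the step of a 2.5-fold lower number from compound 1 to compound 3 (0.40 log units; beyond the scatter) and the step of a 2.5-fold lower number from compound 2 to compound 3 (0.40 log units; beyond the scatter) lie beyond the scatter, so compound 3 stands apart from the other two, while compound 1 and compound 2 sit within the scatter of each other, as the step of no change at the digits printed from compound 1 to compound 2 (within the scatter) shows.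

Compound 4, `CCN(CC)C(=O)n1cc(Cc2ccc(C(=O)NS(=O)(=O)c3ccccc3C)cc2OC)c2cc(NC(=O)OC3CCCC3)ccc21`, differs from compound 3 in one place: diethylamino in place of dimethylamino on a carbonyl carbon. Going by the values given here, no measured step alters the size of this group; the steps that touch the aromatic nitrogen exchange hydrogen, formyl and dimethylcarbamoyl, and the one bearing most directly on the present change, a 2.5-fold lower number from compound 2 to compound 3 (0.40 log units; beyond the scatter), is a modest gain on adding dimethylcarbamoyl. Going from dimethylamino to diethylamino has no precedent in the series, so the expected step of no change at the digits printed from compound 3 to compound 4 (within the scatter) is none beyond the scatter. Compound 4 is therefore estimated at 0.4 nM in this assay, with a range from 0.15 nM to 1 nM.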

Compound 4, half-maximal inhibitory concentration: 0.5 nM
The estimate for compound 4 lay 1.3-fold (0.10 log units) below the measured number; the range from low to high includes it.
By their numbers in this assay, from the lowest: compounds 3, 4, 1 and 2 (each within the scatter of the next, the first and the last beyond it).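

In this assay the carbonyl carbon on the aromatic nitrogen accepts diethylamino in place of dimethylamino, with a 1.3-fold higher number from compound 3 to compound 4 (0.10 log units; within the scatter) as the step, so this first change of size at the position does not move the number beyond the scatter. The diethylcarbamoyl group does not separate from the hydrogen or the formyl group, with a 2.0-fold lower number from compound 2 to compound 4 (0.30 log units; within the scatter) and a 2.0-fold lower number from compound 1 to compound 4 (0.30 log units; within the scatter) as the steps, whereas the dimethylcarbamoyl group of compound 3 does separate from both, though the differences involved are small. Nothing in hand explains these steps.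

Open, as far as these compounds go, is how far the position tolerates further growth, for instance dipropylamino, a longer chain, or piperidine, a ring, on the same carbonyl carbon. Also open, from the compounds shown here alone, is whether a carbamoyl group with hydrogen on its nitrogen would read like the hydrogen compound 2 or like compound 3.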